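The source may report more compounds than this note shows. Statements on the series, on what has been measured and on what is new or still open speak of the compounds shown alone.

Three pyrazoline amides have been measured in a functional assay on PC-3 cells (Homo sapiens) for cytotoxicity, read by MTT assay, with a stated time of 48 h; on this read-out higher numbers stand for weaker inhibition and lower numbers for stronger inhibition. Compound 1, `CC1=NN(C(=O)c2ccc([N+](=O)[O-])cc2)C(c2ccccc2O)C1`, gives 36600 nM. Compound 2, `CCC(=O)N1N=C(C)CC1c1cc(Br)cc(Br)c1O`, gives 28600 nM. Compound 3, `O=C(CCl)N1N=C(c2cc3ccccc3oc2=O)CC1c1ccccc1`, gives 2980 nM, the lowest of the three numbers; the gap to compound 2 and the gap to compound 1 both lie well beyond the usual scatter of repeated measurements, so compound 3 stands clearly apart as the most potent of the set. These three compounds differ from one another in several places at once, so no single structural change can be tied to any of these gaps.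

Compound 4, `NC(=O)C1CCN(CC(=O)N2N=C(c3cc4ccccc4oc3=O)CC2c2ccccc2)CC1`, has not yet been measured. It differs from compound 3 in one place: 4-carbamoylpiperidin-1-yl in place of chloro on a saturated chain carbon bound to a carbonyl carbon. The data hold no comparable exchange on any measured pair, so the size and direction of this step can only be guessed. Because compound 3 sits at 2980 nM, the starting point is known, and a moderate step toward a higher number is expected, as a 3.0-fold higher number from compound 3 to compound 4 (0.48 log units; beyond the scatter). Compound 4 is therefore expected to give about 9000 nM, with a plausible range from 2500 nM to 32000 nM.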

Compound 4, half-maximal inhibitory concentration: 8310 nM
For compound 4 the middle estimate is 1.1-fold (0.03 log units) above the measured one, and the stated range covers the measured number.
By their numbers in this assay, from the lowest: compound 3; then compound 4; then compounds 2 and 1 (each within the scatter of the next).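

In this assay, 4-carbamoylpiperidin-1-yl in place of chloro on a saturated chain carbon bound to a carbonyl carbon gives a 2.8-fold higher number from compound 3 to compound 4 (0.45 log units; beyond the scatter). Within the data shown here, this is the first reading at this position, and it shows that the position accepts a much larger group: 9 heavy atoms and a six-membered non-aromatic ring replace a single chlorine, yet compound 4 still gives 8310 nM, so the chloro is not needed for a number of this order, although removing it comes at a modest cost. Nothing measured here explains why the number rises.

The compounds shown leave open whether the rise goes with the carbamoyl group, with the piperidine ring, or simply with the exchange of chloro for a nitrogen-linked group. A plain piperidin-1-yl, a morpholin-4-yl or a small dimethylamino group on the same carbon would help to separate these parts, and a carboxylic acid in place of the carbamoyl group would probe the far end of the new group.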